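Cycloheptyl in place of cyanophenyl on the imidazole substituent

The source may report more compounds than this note shows. Statements on the series, on what has been measured and on what is new or still open speak of the compounds shown alone.

Measured compounds:
compound 1, `CCC(C)(C)Cc1c[nH]c(CCc2ccc(-c3ccccc3C(=O)O)cc2)n1`, 25 nM
compound 2, `N#Cc1ccc(Cc2cnc(CCc3ccc(-c4ccccc4C(=O)O)cc3)[nH]2)cc1`, 5890 nM
compound 3, `CCCCc1cnc(C(CC)Cc2ccc(-c3ccccc3C(=O)O)cc2)[nH]1`, 2720 nM

In an in vitro functional assay on cells for agonist activity at Bombesin receptor subtype-3 (Homo sapiens), read by luminescence and calcium flux (on this read-out higher numbers stand for an effect only at larger amounts of compound and lower numbers for an effect already at smaller amounts), compound 2 gives 5890 nM, the highest number of the three. Compound 3 stands nearest to it with 2720 nM, a gap beyond the scatter, and compound 1 stands furthest with 25 nM, far beyond the scatter. Compound 1 carries a saturated branched chain where compound 2 carries its 4-cyanophenyl group.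

Compound 4, `O=C(O)c1ccccc1-c1ccc(CCc2ncc(CC3CCCCCC3)[nH]2)cc1`, has not yet been measured in this assay. It differs from compound 2 in one place: cycloheptyl in place of 4-cyanophenyl on a saturated chain carbon bound to an aromatic carbon. The leaving group is aromatic with a nitrile; the entering group is a seven-membered non-aromatic ring of carbon only.

Since compound 1, which also carries a saturated group at this position, gives 25 nM, a large step downward is expected here, well beyond the scatter. The step from compound 2 to compound 4 is estimated at a 98-fold lower number from compound 2 to compound 4 (1.99 log units; beyond the scatter). Compound 4 is therefore expected to give about 60 nM, with a range of 15 nM to 300 nM.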

Compound 4, half-maximal effective concentration: 88 nM
Beside the measured number, compound 4's estimate is 1.5-fold (0.17 log units) below it; low and high end bracket the measured number.
By their numbers in this assay, from the lowest: compound 1; then compound 4; then compound 3; then compound 2.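

In this assay the replacement of 4-cyanophenyl by cycloheptyl gives a 67-fold lower number from compound 2 to compound 4 (1.83 log units; beyond the scatter) and is a large step, beyond the scatter. Within the data shown here, this is the first direct one-place comparison at this position, on a saturated chain carbon bound to an aromatic carbon. It shows that, with the rest of the structure held constant, the group at this position alone can move the number substantially, and that a seven-membered non-aromatic ring of carbon only is tolerated here with a much lower number than the 4-cyanophenyl group.

The change removes the aromatic ring and the nitrile together, so the compounds shown do not separate the two, and a plain phenyl or a cyclohexyl in the same place would be needed to do so. Nothing measured here says why the step is this large.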